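Amine swap on the propoxy tail: piperidine to piperazine

The compounds below may be only part of what the source reports. "The series", "measured", "known", "first", "only" and "open" are said of these compounds alone.

Measured so far:
compound 1, `COc1cc2c(Oc3ccc(NC(=O)c4cn(-c5ccccc5)nn4)cc3F)ccnc2cc1OCCCN1CCCC1` — in a functional assay on A549 cells (Homo sapiens) for cytotoxicity, read by MTT assay, with a stated time of 72 h (a higher number here means a weaker inhibitor, a lower number a stronger inhibitor), compound 1 gives 360 nM
compound 2, `COc1cc2c(Oc3ccc(NC(=O)c4cn(-c5ccccc5)nn4)cc3F)ccnc2cc1OCCCN1CCC(C)CC1` — in this assay compound 2 gives 140 nM

Going by the values given here, compound 2 stands at the lower of the two numbers; the only measured step, a 2.6-fold lower number from compound 1 to compound 2 (0.41 log units; beyond the scatter), is modest but beyond the scatter.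

Compound 3, `COc1cc2c(Oc3ccc(NC(=O)c4cn(-c5ccccc5)nn4)cc3F)ccnc2cc1OCCCN1CCN(C)CC1`, is the next variation: 4-methylpiperazin-1-yl in place of 4-methylpiperidin-1-yl on a saturated chain carbon, three bonds along the chain from an oxygen on an aromatic ring. Among the compounds with values here, no measured step touches this particular exchange; the one step in hand alters the ring size and its carbon count from compound 1 to compound 2, and says nothing about a second nitrogen in the ring. Within the data shown here, with no precedent, the working expectation for compound 3 in this assay is a number close to that of compound 2, with no step beyond the scatter, so a 1.4-fold higher number from compound 2 to compound 3 (0.15 log units; within the scatter) is expected. The estimate for compound 3 is 200 nM, with a range from 70 nM to 600 nM.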

Compound 3, half-maximal inhibitory concentration: 160 nM
Beside the measured number, compound 3's estimate is 1.3-fold (0.10 log units) above it; the range from low to high includes it.
By their numbers in this assay, from the lowest: compounds 2 and 3 (each within the scatter of the next); then compound 1.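

In this assay, the exchange of 4-methylpiperidin-1-yl for 4-methylpiperazin-1-yl on a saturated chain carbon gives a 1.1-fold higher number from compound 2 to compound 3 (0.06 log units; within the scatter), so the two compounds cannot be told apart and this place accepts a second nitrogen in the six-membered ring with no step beyond the scatter. Compared directly with the pyrrolidin-1-yl of compound 1, the 4-methylpiperazin-1-yl group gives a 2.3-fold lower number from compound 1 to compound 3 (0.35 log units; beyond the scatter), a modest step that lies beyond the scatter, as does the one to the 4-methylpiperidin-1-yl group. No available data give a cause for any of these steps.

Open, from the compounds shown here alone, is how a morpholine ring, or a piperazine with a free ring amine, would read at this place. Also open, going by these compounds, is whether a longer chain in place of the propyl link keeps these numbers.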